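Swapping the aryl ester for an aryl sulfonate

The compounds below may be only part of what the source reports. "The series", "measured", "known", "first", "only" and "open" are said of these compounds alone.

In a functional assay on A-375 cells (Homo sapiens) for cytotoxicity, read by MTT assay (a lower number here means a stronger inhibitor, a higher number a weaker inhibitor), compound 2 `C=CC(=O)Oc1cc(/C=C/C(=O)c2ccc(OC)c3c2OC(C)(C)C=C3)ccc1OC` gives 390 nM and compound 3 `COc1cccc(C(=O)Oc2cc(/C=C/C(=O)c3ccc(OC)c4c3OC(C)(C)C=C4)ccc2OC)c1` gives 800 nM. Compound 1 `COc1ccc(/C=C/C(=O)c2ccc(OC)c3c2OC(C)(C)C=C3)cc1OCC=C(C)C` reads > 10000 nM, which is a limit of the assay and not a number. Compound 3 therefore holds the higher of the two true numbers, and compound 2 is its nearest neighbour, through a modest step: a 2.1-fold higher number from compound 2 to compound 3 (0.31 log units; beyond the scatter).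

Compound 4 `COc1ccc(/C=C/C(=O)c2ccc(OC)c3c2OC(C)(C)C=C3)cc1OS(=O)(=O)c1ccc(C)cc1` carries the change ((4-methylphenyl)sulfonyl in place of (3-methoxyphenyl)carbonyl on an oxygen on an aromatic ring), with (4-methylphenyl)sulfonyl in place of (3-methoxyphenyl)carbonyl on an oxygen on an aromatic ring. The steps at this same oxygen are the large at least 25-fold lower number from compound 1 to compound 2 (1.40 log units; beyond the scatter) and the large at least 12-fold lower number from compound 1 to compound 3 (1.09 log units; beyond the scatter). Within the data shown here, no measured step places a sulfonyl group there, so the reading rests on analogy with those two carbonyl groups, and the modest step between compound 2 and compound 3 sets the likely scale. A modest step to a higher number is expected, estimated as a 2.3-fold higher number from compound 3 to compound 4 (0.35 log units; beyond the scatter). For compound 4 the estimated value is 1800 nM, with an expected range of 500 nM to 7000 nM.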

Compound 4, half-maximal inhibitory concentration: 2400 nM
For compound 4 the middle estimate is 1.3-fold (0.12 log units) below the measured one, within the range that was stated.
By their numbers in this assay, from the lowest: compound 2; then compound 3; then compound 4. At a limit, above all of these: compound 1.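

In this assay, a sulfonyl group on this oxygen gives a higher number than either carbonyl group, more so against the vinylcarbonyl (a 6.2-fold higher number from compound 2 to compound 4 (0.79 log units; beyond the scatter)) than against the (3-methoxyphenyl)carbonyl (a 3.0-fold higher number from compound 3 to compound 4 (0.48 log units; beyond the scatter)). The (4-methylphenyl)sulfonyl group still reads lower than the 3-methylbut-2-en-1-yl group (an at least 4.1-fold lower number from compound 1 to compound 4 (0.61 log units; beyond the scatter)), so among the four groups shown, activity at this oxygen is not confined to carbonyl groups. The value of compound 1 is a limit and not a number, so that last step is a bound: the limit of > 10000 nM in this assay, at which 1 of the 4 values shown sits.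

In compound 4 the sulfonyl link and the aryl substitution change together, and the compounds shown do not separate the two. Also open, on these data alone, is how a methanesulfonyl group, a plain benzoyl group or a free hydroxyl on this oxygen would read.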